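A Second Chloro on the Benzyl Side Chain

The source may report more compounds than this note shows. Statements on the series, on what has been measured and on what is new or still open speak of the compounds shown alone.

Compound 3 `CCN1C(=O)CC[C@H]1C(=O)NCc1ccc(Cl)cc1` gives 631 nM in an assay on isolated protein for inhibition of P2X purinoceptor 7 (Homo sapiens) (a higher number here means a weaker inhibitor, a lower number a stronger inhibitor), level with compound 2 `CCN1C(=O)CC[C@H]1C(=O)NCc1ccccc1Cl`, which gives 631 nM; the two stand within the scatter of each other. Compound 1 `CCN1C(=O)CC[C@H]1C(=O)NCc1ccccc1` is known only by a limit, < 1000 nM in this assay (the limit of < 1000 nM in this assay, at which 1 of the 3 values shown sits). Compound 4 `CCN1C(=O)CC[C@H]1C(=O)NCc1ccc(Cl)cc1Cl` differs from compound 3 by chloro in place of hydrogen on an aromatic carbon. Within the data shown here, the steps that bear on this change, a step that the limit leaves unreadable from compound 1 to compound 2 and a step that the limit leaves unreadable from compound 1 to compound 3, cannot be read in size, so they fix no expected size in this assay. Compound 2 and compound 3 show no change between them, and a small step, a 1.6-fold lower number from compound 3 to compound 4 (0.20 log units; within the scatter), is expected. Compound 4 is estimated at 400 nM, with a range from 130 nM to 1300 nM.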

Compound 4, half-maximal inhibitory concentration: 6.31 nM
Compound 4: middle estimate off by 63-fold (1.80 log units), on the high side, outside the stated range (below it).
By their numbers in this assay, from the lowest: compound 4; then compounds 2 and 3 (each within the scatter of the next).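

With both chloro groups on the ring, compound 4 stands well apart in this assay, with a 100-fold lower number from compound 3 to compound 4 (2.00 log units; beyond the scatter) and a 100-fold lower number from compound 2 to compound 4 (2.00 log units; beyond the scatter). Compound 2 and compound 3, each with one chloro, sit level with each other, so only the combination shows how far a change at these positions can move the number.

From the compounds shown here alone, the steps from compound 1 cannot be read, and what one chloro adds stays unknown, as compound 1 is known only by a limit: the limit of < 1000 nM in this assay, at which 1 of the 4 values shown sits. Whether bromo or methyl in place of the added chloro would give a similar step remains open.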